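This account rests on a few compounds, and the source may have more. Where it says the series, first, only, none or still open, it means among the compounds named here.

Of the compounds shown here, two have so far been measured in a functional assay on U-87MG ATCC cells for inhibition, with U-87 MG (Homo sapiens) as the target, read by MTT assay, with a stated time of 72 h; a higher number here means a weaker inhibitor, a lower number a stronger inhibitor. Compound 1 `Cc1noc(C)c1-c1cnc(N)c(Oc2ccc(C(=O)Nc3ccc(Cl)cc3)cc2)n1` gives 15500 nM, and compound 2 `Cn1cc(-c2cnc(N)c(Oc3ccc(C(=O)Nc4ccc(Cl)cc4)cc3)n2)cn1`, which carries a 1-methyl-1H-pyrazol-4-yl in place of the 3,5-dimethyl-1,2-oxazol-4-yl on an aromatic carbon, gives 35800 nM. That exchange is a 2.3-fold higher number from compound 1 to compound 2 (0.36 log units; beyond the scatter), so compound 2 holds the higher of the two numbers, meaning the weaker inhibition of the pair.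

Compound 3 `Cn1cc(-c2cnc(N)c(Oc3ccc(C(=O)Nc4ccc(Cl)cn4)cc3)n2)cn1` differs from compound 2 in a different part of the molecule: 5-chloropyridin-2-yl in place of 4-chlorophenyl on an amide-type nitrogen. Among the compounds with values here, the single measured step concerns the aromatic group on the shared core, not the amide-type nitrogen, and no measured pair shows an exchange of a 4-chlorophenyl for a 5-chloropyridin-2-yl at that position. The available numbers therefore give no basis for a change in either direction, and the expectation for a 1.0-fold lower number from compound 2 to compound 3 (0.01 log units; within the scatter) is a step that stays within the scatter. Compound 3 is accordingly expected to give about 35000 nM in this assay, with a likely range from 12000 nM to 100000 nM.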

Compound 3, half-maximal inhibitory concentration: 22200 nM
Compound 3: middle estimate off by 1.6-fold (0.20 log units), on the high side, and the stated range covers the measured number.
By their numbers in this assay, from the lowest: compounds 1, 3 and 2 (each within the scatter of the next, the first and the last beyond it).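

In this assay, within the data shown here, the first exchange at the amide-type nitrogen is a 1.6-fold lower number from compound 2 to compound 3 (0.21 log units; within the scatter): 5-chloropyridin-2-yl replaces 4-chlorophenyl, so a ring carbon gives way to a ring nitrogen and a hydrogen-bond acceptor enters. Among these compounds, earlier, only the aromatic group on the shared core had changed, so this is the first sign that the group on the amide-type nitrogen can take this ring nitrogen without a difference this assay can separate from repeat scatter, at least in this one pair carrying 1-methyl-1H-pyrazol-4-yl. Nothing available explains this outcome or gives a measured property of either group.

From the compounds shown here alone, it remains open whether 5-chloropyridin-2-yl would behave the same way alongside 3,5-dimethyl-1,2-oxazol-4-yl, the group carried by compound 1. Going by these compounds, it is also open whether a larger change on the amide-type nitrogen, such as a methoxy group or a nitrile in place of the chlorine, or a cyclohexyl ring in place of the aromatic ring, would shift the number beyond the scatter.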